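A Methyl on the Bromomethyl Carbon of Compound 3

A few compounds are considered here, and "the series" means these few. Any claim that something is new, unique, unknown or untested is made for them only; others in the source may bear on it.

Compound 3 `COc1ccc(CN(C(=O)CBr)c2cc(OC)c(OC)c(OC)c2)cc1O` carries a bromomethyl group on the carbonyl carbon of the shared core. In a functional assay on MGC-803 cells (Homo sapiens) for inhibition, read by MTT assay, with a stated time of 48 h (on this read-out higher numbers stand for weaker inhibition and lower numbers for stronger inhibition), compound 3 gives 140 nM, which is the second highest of the three numbers recorded. Its nearest neighbour is compound 1 `COc1ccc(CN(C(=O)CCl)c2cc(OC)c(OC)c(OC)c2)cc1O`, which in this assay gives 84 nM; the step of a 1.7-fold higher number from compound 1 to compound 3 (0.22 log units; within the scatter) stays within the scatter. The furthest is compound 2 `COc1ccc(CN(C(=O)C=C(C)C)c2cc(OC)c(OC)c(OC)c2)cc1O`, which gives 320 nM; the step of a 2.3-fold lower number from compound 2 to compound 3 (0.36 log units; beyond the scatter) is a modest change beyond the scatter, as is a 3.8-fold higher number from compound 1 to compound 2 (0.58 log units; beyond the scatter).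

Compound 4 `COc1ccc(CN(C(=O)C(C)Br)c2cc(OC)c(OC)c(OC)c2)cc1O` differs from compound 3 in one place: methyl in place of hydrogen on a saturated chain carbon bound to a bromine atom and a carbonyl carbon. Within the data shown here, no measured step touches the same position; the three measured steps all exchange the whole group on the carbonyl carbon, and even the largest of them, a 3.8-fold higher number from compound 1 to compound 2 (0.58 log units; beyond the scatter), is only modest. The addition of a single methyl on the saturated chain carbon is a smaller alteration than any of these, so a step within the scatter, or at most a modest rise in the number, is expected. Compound 4 is therefore estimated at 200 nM, with a range from 90 nM to 500 nM, which amounts to an expected step of a 1.4-fold higher number from compound 3 to compound 4 (0.15 log units; within the scatter).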

Compound 4, half-maximal inhibitory concentration: 120 nM
Compound 4: the middle estimate sits 1.7-fold (0.22 log units) above what was measured; low and high end bracket the measured number.
By their numbers in this assay, from the lowest: compounds 1, 4 and 3 (each within the scatter of the next); then compound 2.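

In this assay, among these compounds, the earlier compounds exchanged the whole group on the carbonyl carbon, whereas this pair changes only the saturated chain carbon bound to a bromine atom and a carbonyl carbon, and methyl in place of hydrogen there gives a 1.2-fold lower number from compound 3 to compound 4 (0.07 log units; within the scatter), so bromomethyl and 1-bromoethyl cannot be told apart on this read-out. The 1-bromoethyl group also cannot be told apart from chloromethyl, with a 1.4-fold higher number from compound 1 to compound 4 (0.15 log units; within the scatter), while it is separated from 2-methylprop-1-en-1-yl by a 2.7-fold lower number from compound 2 to compound 4 (0.43 log units; beyond the scatter), which leaves compound 2 as the only one of the four set apart from the others, and only modestly. Nothing available speaks to why the methyl leaves the number within the scatter.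

Going by these compounds, whether this carbon would accept more than a methyl, such as an ethyl or a phenyl group, remains open, as does whether an amine or a hydroxyl group in place of the bromine would keep the number in this range. Among the compounds shown here, it is also open whether the same methyl on the chloromethyl carbon of compound 1 would give a step as small as the one seen on compound 3.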